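Chloro in place of fluoro: cytotoxicity notes

The source may hold more compounds than are shown below. What is called first, only, known or untested is meant among the compounds shown, and "the series" means these compounds.

In an ADME assay on MT4 cells (Homo sapiens) for cytotoxicity, read by MTT assay, with a stated time of 5 days (on this read-out lower numbers stand for higher toxicity in this test and higher numbers for lower toxicity in this test), compound 1 `COc1ccc(NC(=O)COc2ccnc(Nc3ccc(C#N)cc3)n2)cc1` gives > 333000 nM, a limit of the assay and not a number.

Compound 2 `Cc1cnc(Nc2ccc(C#N)cc2)nc1OCC(=O)Nc1ccccc1F` gives > 331000 nM, likewise only a limit, so its place in the series is not defined by a number.

Compound 3 `Cc1cnc(Nc2ccc(C#N)cc2)nc1OCC(=O)Nc1ccccc1Cl` differs from compound 2 in one place: chloro in place of fluoro on an aromatic carbon.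

Among the compounds with values here, no measured step bears on this change, and no shift beyond the scatter is expected in this assay; the expected at least 1.1-fold lower number from compound 2 to compound 3 (0.04 log units; that floor lies within the scatter) is small.

For compound 3 the expected value is 300000 nM, with an estimated range of 100000 nM to 340000 nM.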

Compound 3, half-maximal cytotoxic concentration: 197000 nM
The estimate for compound 3 lay 1.5-fold (0.18 log units) above the measured number; measured number inside the range.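

In this assay, within the data shown here, compound 3 gives 197000 nM, the first true number in this set. At this position, ortho to a large group, chloro in place of fluoro gives an at least 1.6-fold lower number from compound 2 to compound 3 (0.22 log units; that floor lies within the scatter). That step is only a floor, and the change cannot be sized, because compound 2 stands at a limit and not at a number: the limit of > 331000 nM in this assay, at which 1 of the 3 values shown sits.

On these data alone, whether the change truly moves the read-out beyond the scatter stays open. Also open, as far as these compounds go, is how a bromo, methyl or methoxy group at this position would read.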